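Methoxyphenyl in Place of Methylphenyl: Expected Cytotoxicity

This account rests on a few compounds, and the source may have more. Where it says the series, first, only, none or still open, it means among the compounds named here.

Measured compounds:
compound 1 `COc1cc2c(Oc3ccc(NC(=O)c4cc(-c5ccccc5F)ccn4)cc3F)ccnc2cc1OCCCN1CCCCC1` gives 130 nM in a functional assay on NCI-H460 cells (Homo sapiens) for cytotoxicity, read by MTT assay, with a stated time of 72 h; on this read-out lower numbers stand for stronger inhibition and higher numbers for weaker inhibition
compound 2 `COc1cc2c(Oc3ccc(NC(=O)c4cc(-c5ccccc5C)ccn4)cc3F)ccnc2cc1OCCCN1CCN(C)CC1` gives 150 nM in this assay
compound 3 `COc1cc2c(Oc3ccc(NC(=O)c4cc(-c5ccccc5C)ccn4)cc3F)ccnc2cc1OCCCN1CCCC1` gives 420 nM in this assay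

Compound 3 has the highest number of the three, so the weakest inhibition in this set. Within the data shown here, its nearest neighbour is compound 2, from which it differs only in the amine at the end of the chain, and that step, a 2.8-fold higher number from compound 2 to compound 3 (0.45 log units; beyond the scatter), is the only single-point comparison available. Compound 1 and compound 2 differ in two places at once, so their values can only be read side by side.

Compound 4 `COc1ccc(-c2ccnc(C(=O)Nc3ccc(Oc4ccnc5cc(OCCCN6CCCC6)c(OC)cc45)c(F)c3)c2)cc1` arises from compound 3 by the change (4-methoxyphenyl in place of 2-methylphenyl on an aromatic carbon). Among the measured compounds shown here, none of the measured steps touches this aryl position: the one step in hand concerns the amine, not the aryl group, and the aryl groups of compound 1 and compound 2 are each different from both. There is therefore no direct guide for the size or direction of the step in this assay. In the absence of such a guide, the expected step of a 1.2-fold lower number from compound 3 to compound 4 (0.08 log units; within the scatter) is small and may lie within the scatter. Compound 4 is thus estimated at 350 nM, with a range from 120 nM to 1000 nM.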

Compound 4, half-maximal inhibitory concentration: 200 nM
Estimate against measurement, compound 4: 1.8-fold (0.24 log units) above, and the stated range covers the measured number.
By their numbers in this assay, from the lowest: compounds 1, 2 and 4 (each within the scatter of the next); then compound 3.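

In this assay, the aryl group on the six-membered aromatic ring with 1 nitrogen, opposite the ring nitrogen, now has a step of its own: with the pyrrolidine-bearing chain and the rest of the molecule held constant, 4-methoxyphenyl in place of 2-methylphenyl gives a 2.1-fold lower number from compound 3 to compound 4 (0.32 log units; beyond the scatter). This shows that the number responds to this position as well as to the amine at the end of the chain, with a modest step that lies beyond the scatter. Among these compounds, the single step changes both the substituent and where it sits on the phenyl ring, and it adds one oxygen and one hydrogen-bond acceptor, while no measurement here explains the shift.

The compounds shown leave open what 2-methoxyphenyl or 4-methylphenyl would give at this position, and either would help separate the kind of substituent from its location on the phenyl ring. They also leave open whether 4-methoxyphenyl would give a step of similar direction and size on a chain ending in 4-methylpiperazin-1-yl or piperidin-1-yl.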